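The source may report more compounds than this note shows. Statements on the series, on what has been measured and on what is new or still open speak of the compounds shown alone.

Measured so far:
- Compound 1 `O=C1NCCN1c1ccc(S(=O)(=O)Nc2cccc(Br)c2)cc1`: 170 nM
- Compound 2 `Cc1ccc(C)c(NS(=O)(=O)c2ccc(N3CCNC3=O)cc2)c1`: 72 nM

In a functional assay on SK-OV-3 cells (Homo sapiens) for antiproliferative activity, read by sulforhodamine B assay, with a stated time of 48 h (a lower number here means a stronger inhibitor, a higher number a weaker inhibitor), compound 2 holds the lower of the two numbers at 72 nM, which makes it the stronger inhibitor of the pair. The next compound, compound 3 `COc1cccc(NS(=O)(=O)c2ccc(N3CCNC3=O)cc2)c1`, has 3-methoxyphenyl in place of 2,5-dimethylphenyl on a sulfonamide nitrogen.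

Within the data shown here, only one measured step bears on this change, made at the same nitrogen: a 2.4-fold lower number from compound 1 to compound 2 (0.37 log units; beyond the scatter). That modest step came with 2,5-dimethylphenyl in place of 3-bromophenyl. The entering 3-methoxyphenyl shares its numbering with the 3-bromophenyl of compound 1, so part of that step may be given back, although one step is thin evidence. The expected change is a modest rise, a 1.7-fold higher number from compound 2 to compound 3 (0.22 log units; within the scatter). For compound 3 the estimated value is 120 nM, with an expected range of 40 nM to 400 nM.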

Compound 3, half-maximal inhibitory concentration: 240 nM
The estimate for compound 3 lay 2.0-fold (0.30 log units) below the measured number, and the stated range covers the measured number.
By their numbers in this assay, from the lowest: compound 2; then compounds 1 and 3 (each within the scatter of the next).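

In this assay, 3-methoxyphenyl in place of 2,5-dimethylphenyl on the sulfonamide nitrogen gives a 3.3-fold higher number from compound 2 to compound 3 (0.52 log units; beyond the scatter), so the lower number of compound 2 is not kept with this new group. Methoxy in place of bromo gives a 1.4-fold higher number from compound 1 to compound 3 (0.15 log units; within the scatter), so these two groups cannot be told apart here, and compound 2 stands as the strongest of the three, clear of both others. Nothing available explains why these groups differ in this way.

The compounds shown leave open whether both methyl groups of 2,5-dimethylphenyl are needed for the lower number, or whether one alone would do. They also leave open how a phenyl ring carrying an amine or a carboxylic acid would behave on this nitrogen.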